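The compounds below may be only part of what the source reports. "The series", "measured", "known", "first", "only" and "open" are said of these compounds alone.

Working notes on the series. In a functional assay on GBM2 cells (Homo sapiens) for antiproliferative activity, read by WST assay, with a stated time of 72 h (on this read-out higher numbers stand for weaker inhibition and lower numbers for stronger inhibition), compound 1 (`O=C(Nc1ccc(Cl)c(Cl)c1)Nc1cc2ncncc2cc1OCc1ccccc1F`) gives 6000 nM. Compound 3 (`O=C(Nc1ccc(C(F)(F)F)cc1)Nc1cc2ncncc2cc1OCc1cccc(Cl)c1`) gives 4700 nM, within the scatter of that value, while compound 2 (`O=C(Nc1ccc(Cl)c(Cl)c1)Nc1cc2ncncc2cc1OCc1cccc(F)c1`) gives 1500 nM, so compound 1 sits at the high, weaker end of the three together with compound 3.

The next compound is compound 4 (`O=C(Nc1ccccc1F)Nc1cc2ncncc2cc1OCc1ccccc1F`), with this change: 2-fluorophenyl in place of 3,4-dichlorophenyl on an amide-type nitrogen. It places 2-fluorophenyl in place of 3,4-dichlorophenyl on an amide-type nitrogen.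

Within the data shown here, no measured step isolates a change at that place. Among the measured compounds shown here, the only single-place step, a 4.0-fold lower number from compound 1 to compound 2 (0.60 log units; beyond the scatter), is modest and concerns a different place, the fluorophenyl on the saturated chain carbon. It serves only as a rough gauge of size. Compound 3, at 4700 nM, differs from compound 1 in more than one place and gives no clean comparison.

With no direction available from the data, no step beyond the scatter is expected in this assay, though the uncertainty is wide. The estimated change is a 1.2-fold higher number from compound 1 to compound 4 (0.07 log units; within the scatter). For compound 4 the estimated value is 7000 nM, with an expected range of 2500 nM to 20000 nM.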

Compound 4, half-maximal inhibitory concentration: 3600 nM
For compound 4 the middle estimate is 1.9-fold (0.29 log units) above the measured one, within the range that was stated.
By their numbers in this assay, from the lowest: compound 2; then compounds 4, 3 and 1 (each within the scatter of the next).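

Among these compounds, this is the only measured step at the amide-type nitrogen: in this assay, 2-fluorophenyl in place of 3,4-dichlorophenyl gives a 1.7-fold lower number from compound 1 to compound 4 (0.22 log units; within the scatter) and so stays inside the usual scatter. With 2-fluorophenyl held on the saturated chain carbon, exchanging both chlorine atoms for one fluorine does not move the number beyond the scatter. The earlier compounds shown here showed a step beyond the scatter only at the saturated chain carbon, and this place has so far given none. No measurement at hand accounts for this result.

As far as these compounds go, whether the same exchange reads alike with 3-fluorophenyl on the saturated chain carbon, as in compound 2, remains open. Also open, from the compounds shown here alone, is how an amine or a carboxylic acid on that aromatic ring, or a saturated alkyl chain replacing it, would read.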